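This account rests on a few compounds, and the source may have more. Where it says the series, first, only, none or still open, it means among the compounds named here.

Of the compounds shown here, two sharing one core have been tested so far, compound 1 `COc1c(N2C[C@H]3CCCN(C(=O)Cn4cc(CN5C(=O)C(=O)c6cc(F)ccc65)nn4)[C@H]3C2)c(F)cc2c(=O)c(C(=O)O)cn(C3CC3)c12` and compound 2 `COc1c(N2C[C@H]3CCCN(C(=O)Cn4cc(CN5C(=O)C(=O)c6cc(C)ccc65)nn4)[C@H]3C2)c(F)cc2c(=O)c(C(=O)O)cn(C3CC3)c12`. In an ADME assay on Vero cells (Chlorocebus sabaeus) for cytotoxicity, read by MTT assay, with a stated time of 72 h (on this read-out higher numbers stand for lower toxicity in this test and lower numbers for higher toxicity in this test), compound 1 gives 16 ug/mL, while compound 2 gives 64 ug/mL, the higher of the two numbers. The next compound, compound 3 `COc1c(N2C[C@H]3CCCN(C(=O)Cn4cc(CN5C(=O)C(=O)c6cccc(F)c65)nn4)[C@H]3C2)c(F)cc2c(=O)c(C(=O)O)cn(C3CC3)c12`, has not yet been measured. Its structure differs from that of compound 2 as follows: a group of 12 heavy atoms (8 carbon, 1 nitrogen, 2 oxygen, 1 fluorine; one five-membered non-aromatic ring with 1 hetero atom, one six-membered aromatic ring of carbon only) in place of a group of 12 heavy atoms (9 carbon, 1 nitrogen, 2 oxygen; one five-membered non-aromatic ring with 1 hetero atom, one six-membered aromatic ring of carbon only), on a saturated chain carbon bound to an aromatic carbon. Among the measured compounds shown here, only one measured step bears on this change: a 4.0-fold higher number from compound 1 to compound 2 (0.60 log units; beyond the scatter), a modest step beyond the scatter, with methyl in place of fluoro on an aromatic carbon. Compound 3 also loses carbon and gains fluorine relative to compound 2, so a move back toward the lower number is expected, though compound 3 is not identical to compound 1 and the precedent is a single pair. The expected change in this assay is a 2.7-fold lower number from compound 2 to compound 3 (0.43 log units; beyond the scatter). The estimate for compound 3 is 24 ug/mL, with an expected range from 8 ug/mL to 64 ug/mL.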

Compound 3, half-maximal cytotoxic concentration: 32 ug/mL
Compound 3: middle estimate off by 1.3-fold (0.12 log units), on the low side, and the stated range covers the measured number.
By their numbers in this assay, from the lowest: compounds 1, 3 and 2 (each within the scatter of the next, the first and the last beyond it).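

In this assay the change from the methyl-bearing group to the fluorine-bearing group gives a 2.0-fold lower number from compound 2 to compound 3 (0.30 log units; within the scatter) and the comparison with the other fluorine-bearing group gives a 2.0-fold higher number from compound 1 to compound 3 (0.30 log units; within the scatter) so compound 3 cannot be separated from either compound 1 or compound 2, even though those two lie beyond the scatter of each other. The groups of compound 1 and compound 3 have identical atom counts, so a different arrangement of the same atoms in this group on a saturated chain carbon bound to an aromatic carbon produced no step beyond the scatter here. No measurement is available that would explain these numbers.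

The compounds shown leave open how a chloro, methoxy or amino group on this aromatic ring would read in this assay and whether the ring without any such group would fall within the same span. They also leave open whether a methyl group arranged as the fluorine is in compound 3 would match compound 2.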